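The compounds below may be only part of what the source reports. "The series", "measured", "known", "first", "only" and "open" are said of these compounds alone.

Compound 2 `CCOC(=O)c1cnc2c(OC)cccc2c1N1CCN(c2ccc(OC)cc2OC)CC1` holds the only numbered result: in a functional assay on HEK cells for negative allosteric modulation of metabotropic glutamate receptor 7 (Rattus norvegicus), read by fluorescence and calcium flux, with stated times of 142 s, 120 s and 40 s (a higher number here means a weaker inhibitor, a lower number a stronger inhibitor), compound 2 gives 1900 nM. Compound 1 `CCOC(=O)c1cnc2c(OC)cccc2c1N1CCN(c2ccccc2OC(F)(F)F)CC1` reaches only a limit of the assay, giving > 30000 nM in this assay, as the limit of > 30000 nM in this assay, at which 1 of the 2 values shown sits, records. Among the compounds with values here, the single measured step, an at least 15-fold lower number from compound 1 to compound 2 (1.19 log units; beyond the scatter), came from changing the phenyl group on the ring amine nitrogen. Compound 3 `CCOC(=O)c1cnc2c(OC)cccc2c1N1CCN(c2c(OC)cccc2OC)CC1` changes that same group again, this time (2,6-dimethoxyphenyl in place of 2,4-dimethoxyphenyl on an amine nitrogen in a ring). Within the data shown here, since the one measured step was large, a further rearrangement of the methoxy groups is expected to move the number, and compound 3 is estimated at 6000 nM, between 1500 nM and 30000 nM, a step of a 3.2-fold higher number from compound 2 to compound 3 (0.50 log units; beyond the scatter) in the weaker direction.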

Compound 3, half-maximal inhibitory concentration: 800 nM
Beside the measured number, compound 3's estimate is 7.5-fold (0.88 log units) above it; the measured number lies below the stated range.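

Where the two methoxy groups sit on the phenyl ring matters in its own right: with the same atoms joined differently, this assay shows a 2.4-fold lower number from compound 2 to compound 3 (0.38 log units; beyond the scatter). Replacing the 2-(trifluoromethoxy)phenyl group with the 2,6-dimethoxyphenyl group gives an at least 37-fold lower number from compound 1 to compound 3 (1.57 log units; beyond the scatter). That step starts from compound 1, which stands at a limit of the assay and not at a number: the limit of > 30000 nM in this assay, at which 1 of the 3 values shown sits.

Going by these compounds, whether a single methoxy group would be enough, and how an ethoxy group or a chlorine on the phenyl ring would read, stays open. So does replacing the ethyl ester with a carboxylic acid or an amide.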